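From Vinyl to Chloromethyl on a Carbonyl Carbon

This account rests on a few compounds, and the source may have more. Where it says the series, first, only, none or still open, it means among the compounds named here.

In a functional assay on Rec1 cells (Homo sapiens) for inhibition, read by luminescence and CellTiter-Glo, with a stated time of 72 h (on this read-out lower numbers stand for stronger inhibition and higher numbers for weaker inhibition), compound 1 `CCOC(=O)c1cc(-c2ccc(Oc3ccccc3)cc2)nn1Cc1cccc(NC(=O)CCl)c1` gives 400 nM and compound 2 `C=CC(=O)Nc1cccc(Cn2nc(-c3ccc(Oc4ccccc4)cc3)cc2CO)c1` gives 1300 nM, the higher of the two numbers, with a gap beyond the scatter. Compound 3 `O=C(CCl)Nc1cccc(Cn2nc(-c3ccc(Oc4ccccc4)cc3)cc2CO)c1` departs from compound 2 by chloromethyl in place of vinyl on a carbonyl carbon, with chloromethyl in place of vinyl on a carbonyl carbon. Compound 1, at 400 nM, also carries chloromethyl there, although it differs elsewhere too, so it offers only limited guidance. A modest step to a lower number is expected, estimated as a 2.2-fold lower number from compound 2 to compound 3 (0.34 log units; beyond the scatter). Compound 3 is expected at 600 nM, with an estimated range of 200 nM to 1800 nM.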

Compound 3, half-maximal inhibitory concentration: 400 nM
Beside the measured number, compound 3's estimate is 1.5-fold (0.18 log units) above it; measured number inside the range.
By their numbers in this assay, from the lowest: compounds 1 and 3 (each within the scatter of the next); then compound 2.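

With hydroxymethyl held constant, the change on the carbonyl carbon can now be read directly: chloromethyl in place of vinyl gives a 3.3-fold lower number from compound 2 to compound 3 (0.51 log units; beyond the scatter) in this assay. With chloromethyl held constant, hydroxymethyl in place of ethoxycarbonyl on an aromatic carbon gives no change at the digits printed from compound 1 to compound 3 (within the scatter), so this assay does not separate those two groups there. Nothing available explains either result. From the compounds shown here alone, whether the vinyl-to-chloromethyl step would hold with ethoxycarbonyl on the aromatic carbon remains open. So does how a carboxylic acid at that position, or a longer chain on the carbonyl carbon, would read.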